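Amide to carbamate at the capping group of compound 2

This account rests on a few compounds, and the source may have more. Where it says the series, first, only, none or still open, it means among the compounds named here.

Of the compounds shown here, two have been measured in an assay on isolated protein for inhibition of cathepsin S (Homo sapiens); a higher number here means a weaker inhibitor, a lower number a stronger inhibitor. Compound 1 `O=C(N[C@@H](CC1CCCCC1)C(=O)NCCNc1ccc(OC(F)(F)F)cc1)c1ccc(-c2cccc(C(F)(F)F)c2)o1` gives 11 nM. Compound 2 `C[C@@H](CNc1ccc(OC(F)(F)F)cc1)NC(=O)[C@H](CC1CCCCC1)NC(=O)C1CCOC1` gives 21 nM, a number that sits within the usual scatter of what compound 1 shows, so the two cannot be told apart on these data alone. Compound 2 shares with compound 1 the cyclohexylmethyl-bearing amino acid and the trifluoromethoxy-substituted aniline, but carries a shorter linker and a different cap on the amide-type nitrogen.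

Compound 3 `C[C@@H](CNc1ccc(OC(F)(F)F)cc1)NC(=O)[C@H](CC1CCCCC1)NC(=O)O[C@H]1CCOC1` is not yet measured. It differs from compound 2 in one place: (oxolan-3-yl)oxy in place of oxolan-3-yl on a carbonyl carbon. The cap thus passes from an amide to a carbamate, with one more oxygen and one defined stereocentre in the entering group. Within the data shown here, no measured pair in this set makes a comparable change, so there is no step to draw on. The step from compound 2 to compound 3 is therefore expected to be small, at most a mild move to a weaker inhibitor and quite possibly nothing beyond the scatter, a 1.3-fold higher number from compound 2 to compound 3 (0.12 log units; within the scatter). For compound 3 in this assay the estimate is 28 nM, with a range from 8 nM to 100 nM.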

Compound 3, inhibition constant: 49 nM
For compound 3 the middle estimate is 1.8-fold (0.24 log units) below the measured one; low and high end bracket the measured number.
By their numbers in this assay, from the lowest: compounds 1 and 2 (each within the scatter of the next); then compound 3.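

In this assay, among these compounds, the exchange of oxolan-3-yl for (oxolan-3-yl)oxy on a carbonyl carbon whose other neighbour is an amide-type nitrogen gives the first step that can be read in this set: a 2.3-fold higher number from compound 2 to compound 3 (0.37 log units; beyond the scatter). The step is modest but beyond the scatter, so this position does respond to the passage from amide to carbamate, and the response is a move to a weaker inhibitor, with the five-membered ring itself kept in both compounds. Nothing in hand accounts for this step.

The compounds shown leave open whether the step belongs to the oxygen added on the carbonyl carbon or to the defined stereocentre of the entering group, as the two arrive together in compound 3. They also leave open how (oxolan-3-yl)methyl, with a carbon in place of that oxygen, or a plain ethoxy on the same carbonyl carbon would read in this assay, and whether the opposite stereocentre in (oxolan-3-yl)oxy would give a similar number.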